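The source may report more compounds than this note shows. Statements on the series, on what has been measured and on what is new or still open speak of the compounds shown alone.

Measured so far in a functional assay on HeLa cells (Homo sapiens) for antiproliferative activity, read by MTT assay, with a stated time of 48 h; on this read-out higher numbers stand for weaker inhibition and lower numbers for stronger inhibition:
Compound 1 `COc1cc(-c2nnc3c(OC(C)C)cc(-c4ccc5[nH]ccc5c4)cn23)cc(OC)c1OC` gives 261 nM
Compound 2 `CCOc1cc(-c2ccc3c(ccn3C)c2)cn2c(-c3cc(OC)c(OC)c(OC)c3)nnc12` gives 210 nM
Compound 3 `COc1cc(-c2nnc3c(OC)cc(-c4ccc5c(ccn5C)c4)cn23)cc(OC)c1OC` gives 15 nM

Compound 3 holds the lowest number of the three, beyond the scatter from both others. Compound 4 `COc1cc(-c2nnc3c(OC(C)C)cc(-c4ccc5c(ccn5C)c4)cn23)cc(OC)c1OC` differs from it by one change, (isopropyl in place of methyl on an oxygen on an aromatic ring), with methoxy becoming isopropoxy. Among the measured compounds shown here, the one measured step at this oxygen, a 14-fold lower number from compound 2 to compound 3 (1.15 log units; beyond the scatter), is large and leaves compound 3 with the smaller chain. Differing from compound 4 elsewhere, compound 1 also carries isopropoxy and gives 261 nM in the same test. A large rise in this assay is therefore expected. The estimated change is a 19-fold higher number from compound 3 to compound 4 (1.27 log units; beyond the scatter), of similar size. For compound 4 the estimated value is 280 nM, with an expected range from 90 nM to 800 nM overall.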

Compound 4, half-maximal inhibitory concentration: 503 nM
Estimate against measurement, compound 4: 1.8-fold (0.25 log units) below; measured number inside the range.
By their numbers in this assay, from the lowest: compound 3; then compounds 2, 1 and 4 (each within the scatter of the next, the first and the last beyond it).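

In this assay, the step of a 34-fold higher number from compound 3 to compound 4 (1.53 log units; beyond the scatter) shows that isopropyl on this oxygen costs far more than the earlier ethoxy comparison revealed. Most of that loss already appears with ethoxy, since the further step a 2.4-fold higher number from compound 2 to compound 4 (0.38 log units; beyond the scatter) is only modest. With isopropoxy in place, the step of a 1.9-fold higher number from compound 1 to compound 4 (0.28 log units; within the scatter) shows that methyl in place of hydrogen on the aromatic nitrogen makes no difference beyond the scatter. On these data alone, whether a free hydroxyl or a straight propyl chain on this oxygen would fit this trend remains open. Nothing available explains why the size of this chain matters so much.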